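A few compounds are considered here, and "the series" means these few. Any claim that something is new, unique, unknown or untested is made for them only; others in the source may bear on it.

Of the compounds shown here, two have so far been tested in a functional assay on SW-620 cells (Homo sapiens) for cytotoxicity; on this read-out higher numbers stand for weaker inhibition and lower numbers for stronger inhibition. Compound 1 `CS(=O)(=O)c1ccc2nc(NC(=O)CCCCC(=O)NO)sc2c1` only reaches the limit of the assay, > 30 ug/mL, so no number is known for it. Within the data shown here, compound 2 `COc1ccc2nc(NC(=O)CCCCCCC(=O)NO)sc2c1` gives 0.96 ug/mL, the one real number measured so far. Compound 3 `O=C(CCCCCCC(=O)Nc1nc2ccccc2s1)NO` differs from compound 2 in a single place: hydrogen in place of methoxy on an aromatic carbon. Among the measured compounds shown here, no measured pair yet shows what such a change does in this assay. The expected step of a 1.6-fold higher number from compound 2 to compound 3 (0.19 log units; within the scatter) is small, at most a slight weakening. Compound 3 is therefore estimated at 1.5 ug/mL, within a range from 0.5 ug/mL to 5 ug/mL.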

Compound 3, half-maximal inhibitory concentration: 4.01 ug/mL
Compound 3: middle estimate off by 2.7-fold (0.43 log units), on the low side, and the stated range covers the measured number.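

Swapping methoxy for hydrogen on this aromatic carbon gives a 4.2-fold higher number from compound 2 to compound 3 (0.62 log units; beyond the scatter) in this assay, the first measured pair to show what this change does. The position therefore matters on this read-out, and here methoxy goes with stronger inhibition than hydrogen. Nothing in the data shown accounts for the size of this step.

Going by these compounds, whether an amine or a fluorine on this same carbon would give a lower or higher number remains open. So does whether this change would give a similar step with a shorter chain.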